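Ethynyl for Iodo on a Selenium-Bearing Core

The compounds below may be only part of what the source reports. "The series", "measured", "known", "first", "only" and "open" are said of these compounds alone.

The measured compounds:
Compound 1, `Ic1nc2ccccc2[se]1`: in a functional assay on NCI-H522 cells (Homo sapiens) for cytotoxicity, with a stated time of 3 days (a higher number here means a weaker inhibitor, a lower number a stronger inhibitor), compound 1 gives > 40000 nM, a limit of the assay rather than a number.
Compound 2, `C#CCNC(=O)c1cscn1`: in this assay compound 2 gives > 40000 nM, again a limit of the assay and not a number.

Among the measured compounds shown here, compound 1 therefore stands at the edge of what this assay can report; its value is a limit, and the same holds for the only other value in hand: the limit of > 40000 nM in this assay, at which 2 of the 2 values shown sit. For the measured compounds named here, no pair of measured compounds differs in a single place, so no measured step exists to lean on.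

Compound 3, `C#Cc1nc2ccccc2[se]1`, has not yet been measured. It differs from compound 1 in one place: ethynyl in place of iodo on an aromatic carbon. The two measured values give no sign that a change of this kind moves the half-maximal inhibitory concentration in either direction, so the account expects no step beyond the scatter of this assay.

Compound 3 is thus estimated at 40000 nM, with a range of 10000 nM to 100000 nM, and most likely reported only as a limit. The step this estimate means is a number no higher from compound 1 to compound 3 (the limit leaves the size open), an expectation and no more.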

Compound 3, half-maximal inhibitory concentration: 2170 nM
Compound 3: the middle estimate sits 18-fold (1.27 log units) above what was measured, and the stated range ends above it.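

The aromatic carbon next to the ring nitrogen and next to the ring selenium turns out to respond to the group it carries: in this assay, ethynyl in place of iodo brings an at least 18-fold lower number from compound 1 to compound 3 (1.26 log units; beyond the scatter). Compound 3 is the first of the compounds shown to give a value inside the range the assay can report, and this is the first step that can be read at all, so exchanging the single iodine atom for the two carbons of ethynyl, with its triple bond, is enough to bring the shared core into that range. The full size of the step stays unknown because compound 1 stands at a limit of the assay and not at a number: the limit of > 40000 nM in this assay, at which 2 of the 3 values shown sit.

Going by these compounds, whether the triple bond itself counts, or whether a methyl, a vinyl group, a nitrile or an amine at this place would give a value like that of compound 3, stays open. Equally open, on these data alone, is what the selenium contributes to the result, a question that a sulfur atom in its place on the shared core would address.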